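A few compounds are considered here, and "the series" means these few. Any claim that something is new, unique, unknown or untested is made for them only; others in the source may bear on it.

Measured compounds:
compound 1 `COc1ccc(C(=O)NO)cc1OCc1noc(-c2ccccc2)n1` — 36500 nM
compound 2 `COc1ccc(C(=O)NO)cc1OCc1noc(-c2cccc(Cl)c2)n1` — 9220 nM

In an assay on isolated protein for inhibition of sphingomyelin phosphodiesterase (Homo sapiens), read by fluorescence, with a stated time of 30 min (a higher number here means a weaker inhibitor, a lower number a stronger inhibitor), compound 2 gives 9220 nM, the lowest of the two numbers recorded; its nearest neighbour is compound 1, which in this assay gives 36500 nM. Going by the values given here, the only measured step, a 4.0-fold lower number from compound 1 to compound 2 (0.60 log units; beyond the scatter), is a modest one and comes from a chloro in place of a hydrogen on an aromatic carbon.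

Compound 3 `COc1ccc(C(=O)NO)cc1OCc1noc(-c2ccc(Cl)cc2)n1` differs from compound 2 only in 4-chlorophenyl in place of 3-chlorophenyl on an aromatic carbon. Among the compounds with values here, no measured step moves a substituent from one ring position to another, so the single step of a 4.0-fold lower number from compound 1 to compound 2 (0.60 log units; beyond the scatter) bears on this change only loosely: it shows that a chloro on that ring helps, not where it sits best. With the same atoms joined differently, no movement beyond the scatter is expected. Compound 3 is therefore estimated to give 9000 nM in this assay, within 3000 nM to 30000 nM. That estimate means a step of a 1.0-fold lower number from compound 2 to compound 3 (0.01 log units; within the scatter), which is expected to stay within the scatter.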

Compound 3, half-maximal inhibitory concentration: 21600 nM
Estimate against measurement, compound 3: 2.4-fold (0.38 log units) below; the range from low to high includes it.
By their numbers in this assay, from the lowest: compound 2; then compounds 3 and 1 (each within the scatter of the next).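

In this assay the place of the chloro on the phenyl group proves to matter: the step to 4-chlorophenyl in place of 3-chlorophenyl gives a 2.3-fold higher number from compound 2 to compound 3 (0.37 log units; beyond the scatter) and so separates two groups with the same atoms. Measured against the parent without chloro, the 4-chlorophenyl group gives a 1.7-fold lower number from compound 1 to compound 3 (0.23 log units; within the scatter) and cannot be told apart from it. Among these compounds, the clear benefit of adding chloro therefore belongs to the 3-chlorophenyl group alone, not to chloro on that ring wherever it sits. No supporting measurement bears on why the two placements differ.

The compounds shown leave open whether fluoro, methoxy or an amine in place of chloro would show the same difference between these two placements. They also leave open whether that difference would persist with changes elsewhere on the shared core.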